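This account rests on a few compounds, and the source may have more. Where it says the series, first, only, none or still open, it means among the compounds named here.

Of the compounds shown here, three that share one core have been tested in an assay on microsomes from intestine for inhibition of acyl-CoA:cholesterol acyltransferase (Oryctolagus cuniculus); a lower number here means a stronger inhibitor, a higher number a weaker inhibitor. Compound 1 `CCCCCCCC/C=C/CCCCCCC(C)(C)C(=O)Nc1c(OC)cc(OC)cc1OC` gives 44 nM. Compound 2 `CCCCCCCCC(C)(C)C(=O)Nc1c(OC)cc(OC)cc1OC`, which carries a shorter chain, gives 59 nM. Compound 3 `CCCCCCCCCCCCCCC(C)(C)C(=O)Nc1c(OC)cc(OC)cc1OC` gives 44 nM. On these numbers compound 3 stands level with compound 1, the two together giving the lowest values of the three, while the gap to compound 2, a 1.3-fold lower number from compound 2 to compound 3 (0.13 log units; within the scatter), lies within the scatter, so none of the three can be called the stronger inhibitor.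

Compound 4 `CCCCCCCCCCCCCCCCC(C)(C)C(=O)Nc1c(OC)cc(OC)cc1OC` has not yet been measured. It differs from compound 3 by ethyl in place of hydrogen on a saturated chain carbon, ten or more bonds along the chain from a carbonyl carbon. For the measured compounds named here, three measured steps bear on such a change in chain length. The step of a 1.3-fold higher number from compound 1 to compound 2 (0.13 log units; within the scatter) and the step of no change at the digits printed from compound 1 to compound 3 (within the scatter) both lie within the scatter, and so does a 1.3-fold lower number from compound 2 to compound 3 (0.13 log units; within the scatter). Changing the length of the chain has thus produced no movement beyond the scatter among compounds 1, 2 and 3, and a further short extension is expected to behave the same way. The expected step is a 1.0-fold higher number from compound 3 to compound 4 (0.01 log units; within the scatter), that is, nothing beyond the scatter. Compound 4 is therefore estimated at 45 nM, with a range from 22 nM to 90 nM.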

Compound 4, half-maximal inhibitory concentration: 87 nM
The estimate for compound 4 lay 1.9-fold (0.29 log units) below the measured number, and the stated range covers the measured number.
By their numbers in this assay, from the lowest: compounds 1, 3, 2 and 4 (each within the scatter of the next).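

In this assay, ethyl in place of hydrogen on a saturated chain carbon, ten or more bonds along the chain from a carbonyl carbon, gives a 2.0-fold higher number from compound 3 to compound 4 (0.30 log units; within the scatter), so even this far out along the chain the added carbons produce no movement that can be told from assay noise. Set against the other two compounds, the picture is the same, with a 1.5-fold higher number from compound 2 to compound 4 (0.17 log units; within the scatter) and a 2.0-fold higher number from compound 1 to compound 4 (0.30 log units; within the scatter); the steps to compound 4 from compound 1 and compound 3 are the largest seen in this small series, yet all four compounds remain within the scatter, and no trend with chain length can be claimed. No independent measurement is available that would help to interpret these numbers.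

For the compounds shown here, still open is whether a longer chain than the one in compound 4, or a shorter one than in compound 2, would finally produce a step beyond the scatter. Also open, from the compounds shown here alone, is what a polar group at the far end of the chain, such as a carboxylic acid or an amine, would do to the number in this assay.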